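A Chloropyridinyl Ether in Place of a Chlorophenyl Ether

The compounds below may be only part of what the source reports. "The series", "measured", "known", "first", "only" and "open" are said of these compounds alone.

Compound 1 `O=C1NC(=O)C(Cc2ccc(Oc3cccc(Cl)c3)cc2)S1` bears a 3-chlorophenyl group on the ether oxygen of the shared core. In a functional assay for agonist activity at Free fatty acid receptor 1 (Homo sapiens), read by FLIPR, in the presence of a further agent that is not named here (a higher number here means that more compound is needed for the effect, a lower number that less compound is needed), compound 1 gives 318 nM, the highest of the three numbers recorded. Compound 3 `O=C1NC(=O)C(Cc2ccc(Oc3cc(Cl)cc(Cl)c3)cc2)S1` gives 207 nM in this assay, and the step of a 1.5-fold lower number from compound 1 to compound 3 (0.19 log units; within the scatter) lies within the scatter. For the measured compounds named here, compound 2 `O=C1NC(=O)C(Cc2ccc(Oc3cccc4ccccc34)cc2)S1` gives 135 nM in this assay; no single-point step links it to compound 1, and its number stands beyond the scatter from that of compound 1.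

Compound 4 `O=C1NC(=O)C(Cc2ccc(Oc3ccc(Cl)cn3)cc2)S1` arises from compound 1 by the change (5-chloropyridin-2-yl in place of 3-chlorophenyl on an oxygen on an aromatic ring). Going by the values given here, no measured step bears directly on this change: the only step recorded puts chloro in place of hydrogen on an aromatic carbon and stays within the scatter, and nothing measured here exchanges a ring carbon for a ring nitrogen. On that basis no step beyond the scatter is expected in either direction in this assay for compound 4. Compound 4 is therefore estimated at 300 nM, with a range from 120 nM to 750 nM. This estimate means an expected step of a 1.1-fold lower number from compound 1 to compound 4 (0.03 log units; within the scatter).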

Compound 4, half-maximal effective concentration: 1870 nM
Compound 4: middle estimate off by 6.2-fold (0.79 log units), on the low side; measured number above the stated range.
By their numbers in this assay, from the lowest: compounds 2, 3 and 1 (each within the scatter of the next, the first and the last beyond it); then compound 4.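

Exchanging 3-chlorophenyl for 5-chloropyridin-2-yl on the ether oxygen gives a 5.9-fold higher number from compound 1 to compound 4 (0.77 log units; beyond the scatter) in this assay, so this position responds to a change within the ring itself, beyond the scatter, whereas the earlier step with an added chloro, a 1.5-fold lower number from compound 1 to compound 3 (0.19 log units; within the scatter) in the same assay, stayed within it. The entering group has the same number of heavy atoms as the one it replaces, but it has a ring nitrogen and counts a hydrogen-bond acceptor, so the step comes with no change in the size of the group by that count. Nothing available explains why the number rises at this position.

From the compounds shown here alone, compound 4 changes the ring nitrogen and the placing of the chloro together, and which of the two carries the step stays open. Also open, going by these compounds, is how a pyridin-2-yl group without chloro, or one with methoxy in place of the chloro, would read in this assay.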